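The compounds below may be only part of what the source reports. "The series", "measured", "known", "first", "only" and "open" are said of these compounds alone.

Compound 3 `Cc1cc(O)c(C2=NN(c3ccc(S(N)(=O)=O)cc3)C(/C=C/c3ccccc3)C2)cc1Cl` gives 2400 nM in a functional assay on HCT-116 cells (Homo sapiens) for antiproliferative activity, with a stated time of 48 h; on this read-out higher numbers stand for weaker inhibition of growth and lower numbers for stronger inhibition of growth. Compound 1 `Cc1cc(O)c(C2=NN(c3ccc(S(N)(=O)=O)cc3)C(c3ccccc3O)C2)cc1Cl` gives 1660 nM in this assay, and compound 2 `Cc1cc(O)c(C2=NN(c3ccc(S(N)(=O)=O)cc3)C(c3ccccc3Cl)C2)cc1Cl` gives 1760 nM; the three numbers sit alongside one another, since the steps of a 1.4-fold higher number from compound 1 to compound 3 (0.16 log units; within the scatter) and a 1.4-fold higher number from compound 2 to compound 3 (0.13 log units; within the scatter) both fall within the scatter, as does a 1.1-fold higher number from compound 1 to compound 2 (0.03 log units; within the scatter).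

Compound 4 `COc1ccc(C2CC(c3cc(Cl)c(C)cc3O)=NN2c2ccc(S(N)(=O)=O)cc2)cc1OC` has not yet been measured. It differs from compound 3 in one place: 3,4-dimethoxyphenyl in place of 2-phenylethenyl on a saturated ring carbon. The two measured steps that bear on this change are those onto compound 3 itself, in which an aromatic ring on that same saturated ring carbon gave way to a 2-phenylethenyl group: from compound 1 a 1.4-fold higher number from compound 1 to compound 3 (0.16 log units; within the scatter) and from compound 2 a 1.4-fold higher number from compound 2 to compound 3 (0.13 log units; within the scatter). Both were within the scatter, so replacing one aromatic ring by another at this position, or swapping it for a 2-phenylethenyl group, has so far not moved the read-out beyond the scatter. On that basis compound 4 is expected to stay near compound 3 in this assay, with a step of a 1.3-fold lower number from compound 3 to compound 4 (0.10 log units; within the scatter) that is expected to lie within the scatter. The estimate for compound 4 is 1900 nM, with a range from 900 nM to 4000 nM.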

Compound 4, concentration for 50% growth inhibition: 1720 nM
Estimate against measurement, compound 4: 1.1-fold (0.04 log units) above; measured number inside the range.
By their numbers in this assay, from the lowest: compounds 1, 4, 2 and 3 (each within the scatter of the next).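

In this assay, the saturated ring carbon next to the ring nitrogen also accepts a 3,4-dimethoxyphenyl group without leaving the scatter, as the steps show: a 1.4-fold lower number from compound 3 to compound 4 (0.14 log units; within the scatter), a 1.0-fold lower number from compound 2 to compound 4 (0.01 log units; within the scatter) and a 1.0-fold higher number from compound 1 to compound 4 (0.02 log units; within the scatter). Until now this position had carried only 2-hydroxyphenyl, 2-chlorophenyl and 2-phenylethenyl, so the flat read-out now extends to a group with 10 heavy atoms, 2 oxygen atoms and 2 hydrogen-bond acceptors, and to an aromatic ring bearing two methoxy groups. The data offer no measured explanation for why these changes leave the read-out within the scatter.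

Going by these compounds, all four compounds carry a six-membered aromatic ring of carbon only in the group at this position, so it remains open whether a group without such a ring, such as a simple methyl, a longer alkyl chain, an amine or a carboxylic acid, would also stay within the scatter. The 4-sulfamoylphenyl and 5-chloro-2-hydroxy-4-methylphenyl groups are the same throughout, so these compounds say nothing about changes in those places.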